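The source may report more compounds than this note shows. Statements on the series, on what has been measured and on what is new or still open speak of the compounds shown alone.

Compound 1 `Cn1c(=O)c(C(=O)NCCN)c(O)c2ccccc21`: 5.6%
Compound 2 `NCCNC(=O)c1c(O)c2ccccc2n(-c2ccccc2)c1=O`: 7.2%

In a functional assay, with a stated time of 20 min, tested at 0.1 mM (a lower number here means a weaker effect, a higher number a stronger effect of the compound at the concentration tested), compound 1 gives 5.6% and compound 2 gives 7.2%. Compound 2 holds the upper of the two numbers, but the step of a number 1.6 percentage points higher from compound 1 to compound 2 (within the scatter) shows the gap to compound 1 to be within the scatter, so both are simply weak. Compound 3 `O=C(CCCCC1CCSS1)NCCNC(=O)c1c(O)c2ccccc2n(-c2ccccc2)c1=O` differs from compound 2 by a group of 11 heavy atoms (8 carbon, 1 oxygen, 2 sulfur; one five-membered non-aromatic ring with 2 hetero atoms) in place of a hydrogen atom, on an amine nitrogen. Among the measured compounds shown here, no measured step touches this amine nitrogen; the only step known, a number 1.6 percentage points higher from compound 1 to compound 2 (within the scatter), concerns another place and stayed within the scatter. Compound 3 is therefore expected to change little, a step of a number 0.8 percentage points higher from compound 2 to compound 3 (within the scatter). The estimate for compound 3 is 8%, between 2% and 18%.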

Compound 3, a percentage reported as activity, at one concentration (the size of the read-out at that concentration, not a potency): 6.4%
For compound 3 the middle estimate is 1.6 percentage points above the measured one; the measured number falls inside the stated range.
By their numbers in this assay, from the lowest: compounds 1, 3 and 2 (each within the scatter of the next).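

In this assay, among the compounds shown here, this is the first change at the amine nitrogen, and replacing its hydrogen with the group of 11 heavy atoms, which carries a five-membered non-aromatic ring, gives a number 0.8 percentage points lower from compound 2 to compound 3 (within the scatter). This nitrogen therefore accepts a much larger group without a change that can be told apart from the scatter, although the effect remains weak at the concentration tested. Nothing measured here explains this result. Going by these compounds, it remains open whether a carboxylic acid or a longer chain on this nitrogen would give a stronger effect. Also open, on these data alone, is how a simple acetyl group there would compare, which would help show whether the five-membered ring matters.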